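Pyrrolidin-1-yl to 4-methylpiperazin-1-yl on the chloro compound

The source may hold more compounds than are shown below. What is called first, only, known or untested is meant among the compounds shown, and "the series" means these compounds.

Measured so far in a functional assay on HepG2 cells (Homo sapiens) for antiproliferative activity, read by MTT assay, with a stated time of 48 h; a higher number here means a weaker inhibitor, a lower number a stronger inhibitor:
Compound 1 `O=C(CN1CCCC1)Nc1ccc2ncnc(Nc3cccc(C(F)(F)F)c3)c2c1` gives 25200 nM
Compound 2 `CN1CCN(CC(=O)Nc2ccc3ncnc(Nc4cccc(C(F)(F)F)c4)c3c2)CC1` gives > 100000 nM (a limit)
Compound 3 `O=C(CN1CCCC1)Nc1ccc2ncnc(Nc3cccc(Cl)c3)c2c1` gives > 100000 nM (a limit)

Compound 3 stands at > 100000 nM, which is a limit and not a number. Compound 1 is the only one of the three with a numerical value. The step under consideration leads to compound 4 `CN1CCN(CC(=O)Nc2ccc3ncnc(Nc4cccc(Cl)c4)c3c2)CC1`, with 4-methylpiperazin-1-yl in place of pyrrolidin-1-yl on a saturated chain carbon bound to a carbonyl carbon.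

The same exchange has been measured once, on the trifluoromethyl compound, as an at least 3.9-fold higher number from compound 1 to compound 2 (0.59 log units; beyond the scatter). This is the step that bears most directly on the new one. The other measured step, an at least 3.9-fold higher number from compound 1 to compound 3 (0.59 log units; beyond the scatter), changes a different place, but it shows how compound 3 came to its limit. Going by these compounds, both steps end at the limit of > 100000 nM in this assay, at which 2 of the 3 values shown sit, so their true sizes remain open.

In this assay a move to a higher number is therefore expected, and compound 4 will probably be reported only as a limit too. The estimated step is a step that the limit leaves unreadable from compound 3 to compound 4. For compound 4 the expected value is 150000 nM, with an estimated range from 60000 nM to 400000 nM.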

Compound 4, half-maximal inhibitory concentration: > 100000 nM
Compound 4 ended at the assay's limit; the forecaster's own chance of this, stated with the estimate: 85%; the middle value lies beyond the limit too.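

In this assay compound 4 gives > 100000 nM, a limit and not a number. Neither the step from compound 3 to compound 4 nor that from compound 2 to compound 4 can be read, because all three compounds sit at the same limit: the limit of > 100000 nM in this assay, at which 3 of the 4 values shown sit.

The compounds shown leave open how far compound 2, compound 3 and compound 4 actually lie from one another.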